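The source may hold more compounds than are shown below. What is called first, only, known or untested is meant among the compounds shown, and "the series" means these compounds.

Measured so far:
- compound 1, `Cc1ccc(-c2ccc3c(c2)C(=O)C(=O)N3)cc1`, in a functional assay on HepG2 cells (Homo sapiens) for antiproliferative activity, read by MTT assay, with a stated time of 48 h (a higher number here means a weaker inhibitor, a lower number a stronger inhibitor), compound 1 gives 6000 nM
- compound 2, `COc1ccc(-c2ccc3c(c2)C(=O)C(=O)N3)cc1`, in this assay compound 2 gives 960 nM

Compound 2 stands at the lower of the two numbers, and the step of a 6.3-fold lower number from compound 1 to compound 2 (0.80 log units; beyond the scatter) lies beyond the usual scatter. Compound 3, `O=C1Nc2ccc(-c3ccc(C(F)(F)F)cc3)cc2C1=O`, has not yet been tested. It differs from compound 2 by trifluoromethyl in place of methoxy on an aromatic carbon. For the measured compounds named here, the only measured step, a 6.3-fold lower number from compound 1 to compound 2 (0.80 log units; beyond the scatter), concerns the same site on the ring but exchanges a different pair of groups, so it guides the expectation only loosely: it shows that a change at this site can move this assay by a modest amount. Going by the values given here, with no step that swaps methoxy for trifluoromethyl, the direction is uncertain; the estimate leans toward a weaker inhibitor, nearer compound 1 than compound 2. Compound 3 is therefore expected to show a 3.1-fold higher number from compound 2 to compound 3 (0.49 log units; beyond the scatter), with an estimated value of 3000 nM and a range from 800 nM to 12000 nM.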

Compound 3, half-maximal inhibitory concentration: 5430 nM
Compound 3: middle estimate off by 1.8-fold (0.26 log units), on the low side; low and high end bracket the measured number.
By their numbers in this assay, from the lowest: compound 2; then compounds 3 and 1 (each within the scatter of the next).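

In this assay, swapping methoxy for trifluoromethyl gives a 5.7-fold higher number from compound 2 to compound 3 (0.75 log units; beyond the scatter), while swapping methyl for trifluoromethyl gives a 1.1-fold lower number from compound 1 to compound 3 (0.04 log units; within the scatter) and so produces no readable change. The earlier step from methyl to methoxy could have reflected methyl alone being the poor group, but the third compound shows otherwise: of the three groups on this aromatic carbon, only methoxy goes with a clearly lower number, and methyl and trifluoromethyl cannot be told apart. Nothing available explains why methoxy sets itself apart here.

Going by these compounds, it remains open whether this benefit belongs to methoxy alone or extends to related groups on the same carbon, such as ethoxy, hydroxyl or an amine. It is also unclear whether methoxy would give the same benefit elsewhere on the shared core.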